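Methylamino to cyclopropylamino: one open cytotoxicity step

The compounds below may be only part of what the source reports. "The series", "measured", "known", "first", "only" and "open" are said of these compounds alone.

In a functional assay on SK-HEP1 cells (Homo sapiens) for cytotoxicity, read by sulforhodamine B assay, with a stated time of 72 h (a higher number here means a weaker inhibitor, a lower number a stronger inhibitor), compound 1 `OCC1=C(F)[C@@H](n2cnc3c(O)ncnc32)[C@H](O)[C@@H]1O` reports only a limit, > 100000 nM. For the measured compounds named here, compound 2 `CNc1ncnc2c1ncn2[C@@H]1C(F)=C(CO)[C@@H](O)[C@H]1O` gives 2760 nM, the only actual number so far. Going by the values given here, the one measured step, an at least 36-fold lower number from compound 1 to compound 2 (1.55 log units; beyond the scatter), came with methylamino in place of hydroxy on an aromatic carbon. Compound 3 `OCC1=C(F)[C@@H](n2cnc3c(NC4CC4)ncnc32)[C@H](O)[C@@H]1O` differs from compound 2 in one place: cyclopropyl in place of methyl on a nitrogen on an aromatic ring. That measured step is large, but it replaces the whole substituent and gives no size for a change of the group on the nitrogen. Only a small move towards a higher number is therefore expected, possibly nothing beyond the scatter. The estimated change in this assay is a 1.4-fold higher number from compound 2 to compound 3 (0.16 log units; within the scatter). For compound 3 the expected value is 4000 nM, with an estimated range of 1000 nM to 20000 nM.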

Compound 3, half-maximal inhibitory concentration: > 100000 nM
Compound 3 ended at the assay's limit; the forecaster's own chance of this, stated with the estimate: 15%; middle value at least 25-fold (1.39 log units) away from the limit.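

Cyclopropyl in place of methyl on a nitrogen on an aromatic ring gives an at least 36-fold higher number from compound 2 to compound 3 (1.55 log units; beyond the scatter) in this assay, so this nitrogen substituent alone can decide whether a number is reached at all. The earlier step showed only that methylamino differs from hydroxy on an aromatic carbon; it does not extend to every amino substituent, since cyclopropylamino gives no measurable number here. Compound 3 and compound 1 both stand at a limit, not a number, so the step between them cannot be read and the step from compound 2 is a minimum size: the limit of > 100000 nM in this assay, at which 2 of the 3 values shown sit.

For the compounds shown here, with compound 2 the only actual number, the tolerance around methyl on this nitrogen remains undefined. Ethylamino, dimethylamino or an unsubstituted amino group on the same aromatic carbon would show whether the number changes gradually or abruptly.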